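Ester in place of the amide on the pyrrole carbonyl

The source may report more compounds than this note shows. Statements on the series, on what has been measured and on what is new or still open speak of the compounds shown alone.

Compound 1 `CCOC(=O)CN(C)C(=O)c1ccc(C(CC)(CC)c2ccc(OCC(=O)C(C)(C)C)c(C)c2)n1CC`: in an assay on HL-60 cells for agonist activity at vitamin D3 receptor (Homo sapiens), read by microscopy, with a stated time of 96 h (a higher number here means that more compound is needed for the effect, a lower number that less compound is needed), compound 1 gives > 50000 nM, which is a limit of the assay.
Compound 2 `CCn1c(C(=O)NCCN(C)C)ccc1C(CC)(CC)c1ccc(OCC(=O)C(C)(C)C)c(C)c1`: compound 2 gives 77 nM.
Compound 3 `CCn1c(C(=O)N(C)c2ccccc2)ccc1C(CC)(CC)c1ccc(OCC(=O)C(C)(C)C)c(C)c1`: compound 3 gives 18500 nM.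

Compound 3 holds the highest number among the two measured values, with a 240-fold higher number from compound 2 to compound 3 (2.38 log units; beyond the scatter). Compound 4 `C#CC(C)OC(=O)c1ccc(C(CC)(CC)c2ccc(OCC(=O)C(C)(C)C)c(C)c2)n1CC` differs from compound 3 only at the carbonyl: (1-methylprop-2-yn-1-yl)oxy in place of methyl(phenyl)amino on a carbonyl carbon. Among the compounds with values here, both measured steps alter the same carbonyl substituent and bear on this change, an at least 2.7-fold lower number from compound 1 to compound 3 (0.43 log units; beyond the scatter) and a 240-fold higher number from compound 2 to compound 3 (2.38 log units; beyond the scatter), so the carbonyl group governs the outcome strongly within these compounds; no measured step, however, exchanges an amide for an ester. The expected step is therefore uncertain but a 3.7-fold lower number from compound 3 to compound 4 (0.57 log units; beyond the scatter) is estimated. Compound 4 is expected to give 5000 nM, between 500 nM and 50000 nM.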

Compound 4, half-maximal effective concentration: 210 nM
Estimate against measurement, compound 4: 24-fold (1.38 log units) above, and the stated range ends above it.
By their numbers in this assay, from the lowest: compound 2; then compound 4; then compound 3. At a limit, above all of these: compound 1.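

Compound 4 shows that this carbonyl carbon need not carry an amide nitrogen: with (1-methylprop-2-yn-1-yl)oxy in place of methyl(phenyl)amino, there is an 88-fold lower number from compound 3 to compound 4 (1.94 log units; beyond the scatter). The ester also comes close to the best amide, though with a 2.7-fold higher number from compound 2 to compound 4 (0.44 log units; beyond the scatter) the gap stays beyond the scatter. The comparison with the ((ethoxycarbonyl)methyl)(methyl)amino amide is only a bound, an at least 230-fold lower number from compound 1 to compound 4 (2.37 log units; beyond the scatter), and it rests on a limit of the assay: the limit of > 50000 nM in this assay, at which 1 of the 4 values shown sits.

Still open, as far as these compounds go, is whether the triple bond contributes to this gain, which an ethyl ester would address. Also open, from the compounds shown here alone, is how a carboxylic acid on this carbonyl carbon would compare.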